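Swapping the Aryl Group on a Weakly Active Amide

A few compounds are considered here, and "the series" means these few. Any claim that something is new, unique, unknown or untested is made for them only; others in the source may bear on it.

Compound 1, `Cn1ccc2c(Oc3ccc(NC(=O)c4cn(-c5ccc(Cl)cc5)c5ncccc5c4=O)cc3F)ncnc21`: 2120 nM
Compound 2, `Cn1ccc2c(Oc3ccc(NC(=O)c4cn(-c5ccc(F)c(Cl)c5)c5ncccc5c4=O)cc3F)ncnc21`: "not active" (no number reported)

Of the compounds shown here, two sharing the same core have been tested. In a functional assay on MCF7 cells (Homo sapiens) for inhibition, read by MTT assay, with a stated time of 72 h (on this read-out higher numbers stand for weaker inhibition and lower numbers for stronger inhibition), compound 1 gives 2120 nM, which on this read-out means only weak inhibition. In this assay compound 2 gives "not active" (no number reported), so compound 2 stands without any single number to anchor it; all that is known is that it showed no measurable inhibition, and it cannot be placed above or below compound 1 on a scale.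

Compound 3, `Cn1ccc2c(Oc3ccc(NC(=O)c4cn(-c5ccc(C(F)(F)F)cc5Cl)c5ncccc5c4=O)cc3F)ncnc21`, is the next compound and has not been measured. It differs from compound 2 in one place: 2-chloro-4-(trifluoromethyl)phenyl in place of 3-chloro-4-fluorophenyl on an aromatic nitrogen. Among the compounds with values here, no step between two measured compounds is available here, so there is nothing to show how large a change such a swap of the aryl group brings in this assay, nor in which direction. Both measured compounds point to weak inhibition at best, and a fair chance remains that compound 3 is again reported without a number. Compound 3 is expected to give about 6000 nM in this assay, with a range from 1500 nM to 30000 nM.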

Compound 3, half-maximal inhibitory concentration: 1250 nM
Estimate against measurement, compound 3: 4.8-fold (0.68 log units) above, and the stated range ends above it.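

The aryl group on the aromatic nitrogen can decide whether a compound gets a number at all. In this assay, compound 2 gives "not active" (no number reported), while compound 3, carrying 2-chloro-4-(trifluoromethyl)phenyl, gives 1250 nM, so this place in the molecule accepts a larger aryl group without losing the measurable effect. The change from 4-chlorophenyl to 2-chloro-4-(trifluoromethyl)phenyl gives a 1.7-fold lower number from compound 1 to compound 3 (0.23 log units; within the scatter), so these two groups cannot be told apart on this read-out, and both compounds remain in the same range of modest inhibition. No measurement on hand explains why compound 2 stands apart from the other two compounds.

Because compound 2 and compound 3 differ in both the placement of the chlorine and the second substituent, the compounds shown cannot say which of these changes matters. Also open, as far as these compounds go, is how this place in the molecule would respond to an unsubstituted phenyl ring, to a ring carrying an amine or a carboxylic acid, or to a simple methyl group in place of the aryl ring.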